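Nitrofuran amides: tolerance on Vero cells before a new analogue

The source may report more compounds than this note shows. Statements on the series, on what has been measured and on what is new or still open speak of the compounds shown alone.

Three nitrofuran amides share one core and differ only in the group on the amide nitrogen. Compound 1 `O=C(NCCCc1ccc(Cl)cc1)c1ccc([N+](=O)[O-])o1`, compound 2 `O=C(NC1(c2ccccc2)CC1)c1ccc([N+](=O)[O-])o1` and compound 3 `CN(C)c1ccc(C(C)(C)NC(=O)c2ccc([N+](=O)[O-])o2)cc1` were all tested in an ADME assay on Vero cells (Chlorocebus sabaeus) for cytotoxicity, read by MTT assay, with a stated time of 48 h; a higher number here means that more compound is tolerated, a lower number that less compound is tolerated. Compound 1 gives 19000 nM, compound 2 gives 46000 nM and compound 3 gives 79000 nM. Compound 3 thus has the highest number of the three; its gap to compound 2 lies within the usual scatter, while its gap to compound 1 lies beyond it, so only the comparison with compound 1 carries weight.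

Compound 4 `CC(C)(NC(=O)c1ccc([N+](=O)[O-])o1)c1ccc(COc2ccc(Cl)cc2)cc1` is the next analogue. It differs from compound 3 by (4-chlorophenoxy)methyl in place of dimethylamino on an aromatic carbon. Among the compounds with values here, no measured pair shows this exact change, so the expected step in this assay can only be a guess. Because compound 1 gives 19000 nM with a larger substituent than compounds 2 and 3, a lower number for compound 4 seems more likely than a higher one. Compound 4 is therefore expected to give 30000 nM, within 10000 nM to 90000 nM. The expected step from compound 3 to compound 4 is a 2.6-fold lower number from compound 3 to compound 4 (0.42 log units; beyond the scatter), a decrease that may reach beyond the scatter.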

Compound 4, half-maximal cytotoxic concentration: 120000 nM
Compound 4: middle estimate off by 4.0-fold (0.60 log units), on the low side, outside the stated range (above it).
By their numbers in this assay, from the lowest: compound 1; then compounds 2, 3 and 4 (each within the scatter of the next, the first and the last beyond it).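

The exchange of dimethylamino for (4-chlorophenoxy)methyl, on an aromatic carbon para to a large group, gives a 1.5-fold higher number from compound 3 to compound 4 (0.18 log units; within the scatter) in this assay, so the two compounds cannot be told apart. Within the data shown here, this is the first direct view of this position: a group of 9 heavy atoms, carrying a six-membered aromatic ring and a chlorine, stands in place of one of 3 heavy atoms with no measurable change in tolerance on these cells. Nothing measured here explains why the number holds steady across so large a swap.

On these data alone, how a plain phenoxymethyl group without the chlorine, or a carboxylic acid on the same aromatic carbon, would read in this assay remains open. Also open, as far as these compounds go, is whether the ether oxygen matters, which an all-carbon chain of similar length could test.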